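This account rests on a few compounds, and the source may have more. Where it says the series, first, only, none or still open, it means among the compounds named here.

Working notes on the series, with all readings taken from a functional assay on PC-3 cells (Homo sapiens) for cytotoxicity, read by MTT assay, with a stated time of 48 h; a lower number here means a stronger inhibitor, a higher number a weaker inhibitor. Compound 1 `COc1cc(NC(=O)n2cc(-c3ccc(O)cc3)n(-c3cc(OC)c(OC)c(OC)c3)c2=O)cc(OC)c1OC` gives 3000 nM, and compound 2 `COc1ccc(-c2cn(C(=O)Nc3cc(OC)c(OC)c(OC)c3)c(=O)n2-c2cc(OC)c(OC)c(OC)c2)cc1N` gives 10000 nM. Compound 3 `COc1cc(-n2c(-c3ccccc3)cn(C(C)=O)c2=O)cc(OC)c1OC`, which bears an acetyl group, is recorded at > 50000 nM, and this reading is a limit, not a number.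

Compound 4 `COc1ccc(-c2cn(C(C)=O)c(=O)n2-c2cc(OC)c(OC)c(OC)c2)cc1N` keeps the acetyl group and has 3-amino-4-methoxyphenyl in place of phenyl on an aromatic carbon. Within the data shown here, no measured step starts from phenyl. The nearest evidence is a 3.3-fold higher number from compound 1 to compound 2 (0.52 log units; beyond the scatter), a modest step that brings in the same group but replaces 4-hydroxyphenyl and lacks the acetyl group. Compound 2 shows that this group can coexist with a measurable value of 10000 nM in this assay, so a move to a lower number is expected, though its size is poorly fixed. The expected step is an at least 3.3-fold lower number from compound 3 to compound 4 (0.52 log units; beyond the scatter), and a further limit reading remains possible. For compound 4 the estimated value is 15000 nM, within an expected range of 2500 nM to 50000 nM.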

Compound 4, half-maximal inhibitory concentration: 21400 nM
Compound 4: middle estimate off by 1.4-fold (0.15 log units), on the low side; low and high end bracket the measured number.
By their numbers in this assay, from the lowest: compound 1; then compound 2; then compound 4. At a limit, above all of these: compound 3.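

With the acetyl group kept, 3-amino-4-methoxyphenyl in place of phenyl on this aromatic carbon gives an at least 2.3-fold lower number from compound 3 to compound 4 (0.36 log units; beyond the scatter) in this assay, so this change brings the acetyl series to a measurable number. Compound 3 stands at a limit, and the size of the step is only a lower bound because of it: the limit of > 50000 nM in this assay, at which 1 of the 4 values shown sits.
The same entering group gave a 3.3-fold higher number from compound 1 to compound 2 (0.52 log units; beyond the scatter) when 4-hydroxyphenyl left, so the direction of the step differs with the group that leaves, across two pairs that also differ in the acetyl group.

The compounds shown leave open which part of the entering group carries the step, a question that a phenyl bearing only the amine or only the methoxy group would address. Also open, as far as these compounds go, is how 4-hydroxyphenyl reads with the acetyl group kept.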